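Five-membered to Six-membered Ring on a Thiocarbonyl Carbon

The source may report more compounds than this note shows. Statements on the series, on what has been measured and on what is new or still open speak of the compounds shown alone.

Of the compounds shown here, three sharing one core have been tested so far. Compound 1 `CCOC(=O)c1cc(=O)c2cc(CSC(=S)N(C(C)C)C(C)C)ccc2o1` carries a diisopropylamino group on a thiocarbonyl carbon. In a functional assay on MCF7 cells (Homo sapiens) for antiproliferative activity, read by MTT assay, with a stated time of 72 h (a lower number here means a stronger inhibitor, a higher number a weaker inhibitor), compound 1 gives > 25000 nM, which is a limit of the assay and not a number. Compound 2 `CCOC(=O)c1cc(=O)c2cc(CSC(=S)N(C)c3ccccc3)ccc2o1` has methyl(phenyl)amino in that place, and compound 2 gives > 25000 nM, again a limit. Compound 3 `CCOC(=O)c1cc(=O)c2cc(CSC(=S)N3CCCC3)ccc2o1` bears pyrrolidin-1-yl there, and compound 3 gives > 25000 nM, also a limit. So the step that the two limits leave unreadable from compound 1 to compound 2, the step that the two limits leave unreadable from compound 1 to compound 3 and the step that the two limits leave unreadable from compound 2 to compound 3 cannot be read; all three values sit at the limit of > 25000 nM in this assay, at which 3 of the 3 values shown sit. Compound 4 `CCOC(=O)c1cc(=O)c2cc(CSC(=S)N3CCCCC3)ccc2o1` is the next candidate, and its change from compound 3 is piperidin-1-yl in place of pyrrolidin-1-yl on a thiocarbonyl carbon. For the measured compounds named here, none of the measured steps tells how far such a change moves the read-out, every one of them being hidden by the limit. The expectation is that compound 4 also lands at the limit, with an estimated step that the limit leaves unreadable from compound 3 to compound 4 showing no readable movement. Compound 4 is expected to give 30000 nM, estimated between 10000 nM and 100000 nM.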

Compound 4, half-maximal inhibitory concentration: 21900 nM
Compound 4: the middle estimate sits 1.4-fold (0.14 log units) above what was measured, within the range that was stated.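

In this assay compound 4 is the first of these compounds to give a number and not a limit, so this position on a thiocarbonyl carbon can now be read with piperidin-1-yl in place. Only floors can be given for its steps (an at least 1.1-fold lower number from compound 3 to compound 4 (0.05 log units; that floor lies within the scatter) and an at least 1.1-fold lower number from compound 2 to compound 4 (0.05 log units; that floor lies within the scatter) and an at least 1.1-fold lower number from compound 1 to compound 4 (0.05 log units; that floor lies within the scatter)), so no firm ranking of piperidin-1-yl over the other three groups follows from them. The steps among the other three compounds still cannot be read, as those compounds stay together at one limit: the limit of > 25000 nM in this assay, at which 3 of the 4 values shown sit.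

Open, from the compounds shown here alone, is how large the true gap between the five-membered and six-membered rings is. Also open, going by these compounds, is whether morpholin-4-yl, piperazin-1-yl or the larger azepan-1-yl at this place would move the number clearly beyond the scatter.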